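The source may report more compounds than this note shows. Statements on the series, on what has been measured and on what is new or still open speak of the compounds shown alone.

Of the compounds shown here, three have been tested in a functional assay on SH-SY5Y cells (Homo sapiens) for cytotoxicity, read by MTT assay, with a stated time of 48 h (on this read-out higher numbers stand for weaker inhibition and lower numbers for stronger inhibition), so far. Compound 1, with the structure `CC(c1nccs1)C(C#N)(C#N)CCC(F)=C(F)F`, gives only a limit there, recorded as > 120000 nM. Compound 2, with the structure `CC(c1nccs1)C(C#N)C#N`, is the starting point of the step followed here. In this assay compound 2 likewise reaches only a limit, > 120000 nM, so no number is known for it. Compound 3, with the structure `[O-][S+](CCC(F)=C(F)F)c1ncc(-c2ccncc2)s1`, also gives a limit in this assay, namely > 120000 nM. Taken together, the limit of > 120000 nM in this assay, at which 3 of the 3 values shown sit, describes where all three stand: none of them produced a number within the measurable range, so compound 2 cannot be placed above or below the others.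

The next compound is compound 4, with the structure `N#CC(C#N)Cc1nccs1`. The change from compound 2 is hydrogen in place of methyl on a saturated chain carbon bound to an aromatic carbon and a saturated chain carbon. Among the compounds with values here, no step between two measured compounds has been recorded, so there is no measured change of a similar kind to lean on. With every result so far sitting at the limit, the step expected is a step that the limit leaves unreadable from compound 2 to compound 4, that is, none beyond the usual scatter. For compound 4 the estimate in this assay is 150000 nM, with a range from 60000 nM to 400000 nM, and the expectation is that the assay will again report only its limit rather than a number.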

Compound 4, half-maximal inhibitory concentration: > 120000 nM
Compound 4: a limit, no number; the forecaster's own chance of this, stated with the estimate: 85%; the middle value is on the limit's open side.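

Compound 2 and compound 4 both give only a limit, so no step can be read from hydrogen in place of methyl. The compounds shown leave open at what concentration, if any, each would reduce the survival of these cells, and whether this change matters at all, with every result resting on one limit: the limit of > 120000 nM in this assay, at which 4 of the 4 values shown sit.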